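The source may report more compounds than this note shows. Statements on the series, on what has been measured and on what is new or still open speak of the compounds shown alone.

Compound 1 `COc1cc(-c2nn(-c3cccc(NC(=O)c4ccc(Cl)c(C(F)(F)F)c4)c3)cc2-c2ccncc2)ccc1Cl`: 11000 nM
Compound 2 `COc1cc(-c2nn(-c3cccc(NC(=O)Nc4cccc(C(F)(F)F)c4)c3)cc2-c2ccncc2)ccc1Cl`: 1280 nM

Going by the values given here, in a functional assay on 786-0 cells (Homo sapiens) for inhibition, read by sulforhodamine B assay, with a stated time of 48 h (on this read-out lower numbers stand for stronger inhibition of growth and higher numbers for weaker inhibition of growth), compound 2 holds the lowest of the two numbers; the one measured step, an 8.6-fold lower number from compound 1 to compound 2 (0.93 log units; beyond the scatter), separates it from compound 1. Compound 3 `COc1cc(-c2nn(-c3cccc(NC(=O)c4ccccc4)c3)cc2-c2ccncc2)ccc1Cl` differs from compound 2 in one place: phenyl in place of (3-(trifluoromethyl)phenyl)amino on a carbonyl carbon. That step bears on this change only in part, since it exchanged the group on the carbonyl carbon as well, and compound 3 undoes the (3-(trifluoromethyl)phenyl)amino that accompanied the lower number. A return toward compound 1 is expected, with a step of a 4.7-fold higher number from compound 2 to compound 3 (0.67 log units; beyond the scatter). Compound 3 is estimated at 6000 nM, between 2000 nM and 20000 nM.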

Compound 3, concentration for 50% growth inhibition: 1520 nM
Compound 3: middle estimate off by 3.9-fold (0.60 log units), on the high side; measured number outside the range, below it.
By their numbers in this assay, from the lowest: compounds 2 and 3 (each within the scatter of the next); then compound 1.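

In this assay the step of a 1.2-fold higher number from compound 2 to compound 3 (0.07 log units; within the scatter) shows that, on this carbonyl carbon, phenyl and (3-(trifluoromethyl)phenyl)amino cannot be told apart, so the amino link is not required for a number in this range. The step of a 7.2-fold lower number from compound 1 to compound 3 (0.86 log units; beyond the scatter) shows that replacing 4-chloro-3-(trifluoromethyl)phenyl with phenyl alone is enough to give such a number. Nothing available accounts for either result.

On these data alone, it remains open whether the chlorine or the trifluoromethyl in compound 1 accounts for that gap. As far as these compounds go, how a carboxylic acid or an amine on the phenyl would read also remains open.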